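Trifluoromethoxyphenyl replaced by indol-2-yl: an expected step

This account rests on a few compounds, and the source may have more. Where it says the series, first, only, none or still open, it means among the compounds named here.

Measured so far in a functional assay on A549 cells (Homo sapiens) for cytotoxicity, read by MTT assay, with a stated time of 72 h; on this read-out higher numbers stand for weaker inhibition and lower numbers for stronger inhibition:
compound 1 `COc1cc2c(Oc3ccc(NC(=O)N/N=C/c4ccc([N+](=O)[O-])cc4)cc3F)ccnc2cc1OCCCN1CCCC1` gives 460 nM
compound 2 `COc1cc2c(Oc3ccc(NC(=O)N/N=C/c4ccc(C(F)(F)F)cc4)cc3F)ccnc2cc1OCCCN1CCCC1` gives 790 nM
compound 3 `COc1cc2c(Oc3ccc(NC(=O)N/N=C/c4ccc(OC(F)(F)F)cc4)cc3F)ccnc2cc1OCCCN1CCCCC1` gives 590 nM

Compound 3 stands second highest of the three numbers; it lies within the scatter of compound 1 and within the scatter of compound 2, so no order among the three can be claimed. Within the data shown here, the only single-point step measured, a 1.7-fold higher number from compound 1 to compound 2 (0.23 log units; within the scatter), stays within the scatter.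

Compound 4 `COc1cc2c(Oc3ccc(NC(=O)N/N=C/c4cc5ccccc5[nH]4)cc3F)ccnc2cc1OCCCN1CCCCC1` has not yet been measured. It differs from compound 3 by 1H-indol-2-yl in place of 4-(trifluoromethoxy)phenyl on a carbon with a double bond to nitrogen. Among the measured compounds shown here, no measured step bears directly on this change: the one step in hand exchanges a substituent on the aromatic ring, whereas here the whole aromatic group is exchanged for a fused two-ring system carrying a hydrogen-bond donor. The step from compound 1 to compound 2 was small, and the three numbers in hand span a narrow band, so the account expects no step beyond the scatter from compound 3 to compound 4, with a wider range to allow for the larger change, a 1.2-fold lower number from compound 3 to compound 4 (0.07 log units; within the scatter). The estimate for compound 4 in this assay is 500 nM, expected to fall between 150 nM and 1600 nM.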

Compound 4, half-maximal inhibitory concentration: 780 nM
Estimate against measurement, compound 4: 1.6-fold (0.19 log units) below, and the stated range covers the measured number.
By their numbers in this assay, from the lowest: compounds 1, 3, 4 and 2 (each within the scatter of the next).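

In this assay, 1H-indol-2-yl in place of 4-(trifluoromethoxy)phenyl on a carbon with a double bond to nitrogen gives a 1.3-fold higher number from compound 3 to compound 4 (0.12 log units; within the scatter). Among these compounds, the one earlier step exchanged only a substituent on the aromatic ring, whereas this one replaces the whole aromatic group with a fused two-ring group carrying a hydrogen-bond donor, and the result still stays within the scatter, so this place accepts a much larger exchange than the earlier compounds had tested, with no readable effect on the number. Nothing in hand explains why the number holds through this exchange.

The compounds shown leave open whether any group at this place would move the number beyond the scatter, for example a phenyl ring carrying a carboxylic acid or a dimethylamino group, or a cyclohexyl group with no aromatic ring at all. They also leave open whether an indole attached through another ring carbon, or one with a methyl group on its ring nitrogen, would stay within the scatter of compound 4.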